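Phenyl for Benzyl on the Amide Nitrogen

The source may report more compounds than this note shows. Statements on the series, on what has been measured and on what is new or still open speak of the compounds shown alone.

Compound 1, `O=C(CSc1nnc(-c2ccncc2)s1)NCc1ccccc1Cl`, in an ADME assay on HepG2 cells (Homo sapiens) for cytotoxicity, with a stated time of 3 days; a lower number here means that less compound is tolerated, a higher number that more compound is tolerated: "not determined" (no result reported)
Compound 2, `O=C(CSc1nnc(-c2ccncc2)s1)NCc1ccc(Cl)cc1`, in this assay: > 50000 nM

For the measured compounds named here, only two compounds have so far been taken into this assay, and neither gives a single number. For compound 1 the outcome is simply "not determined" (no result reported). Compound 2 reaches the limit of the assay: its result of > 50000 nM is a limit rather than a measured value, as shown by the limit of > 50000 nM in this assay, at which 1 of the 2 values shown sits. Going by the values given here, with one compound unmeasured and the other at a limit, no step between measured compounds can be drawn, so nothing yet shows how a change on the amide nitrogen moves cytotoxicity.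

Compound 3 is `O=C(CSc1nnc(-c2ccncc2)s1)Nc1ccc(Cl)cc1`. It differs from compound 2 in a single place: 4-chlorophenyl in place of 4-chlorobenzyl on an amide-type nitrogen. Since compound 2 sits at the limit, the expected step is a number no higher from compound 2 to compound 3 (the limit leaves the size open), which means no movement beyond the usual scatter, and most likely another limit rather than a number. Compound 3 is therefore estimated at 50000 nM, within a range from 20000 nM to 100000 nM.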

Compound 3, half-maximal cytotoxic concentration: > 50000 nM
Compound 3: only a limit was reported (the forecaster's own chance of this, stated with the estimate: 70%); the middle value lies on the limit itself.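

Compound 2 and compound 3 both end at a limit of the assay rather than at a number, so no step can be read between them: the limit of > 50000 nM in this assay, at which 2 of the 3 values shown sit.

The compounds shown leave open whether 4-chlorophenyl in place of 4-chlorobenzyl on the amide-type nitrogen changes the result in this assay at all.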